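Losing the whole ester: an expectation for compound 4

This account rests on a few compounds, and the source may have more. Where it says the series, first, only, none or still open, it means among the compounds named here.

Compound 1 `O=C(OC1(C(=O)Nc2ccc([N+](=O)[O-])cc2)CCCCC1)c1ccccc1I`: 619 nM
Compound 2 `CCOC(=O)c1ccccc1C(=O)OC1(C(=O)Nc2ccc([N+](=O)[O-])cc2)CCCCC1`: 444 nM
Compound 3 `O=C(/C=C/c1ccccc1)OC1(C(=O)Nc2ccc([N+](=O)[O-])cc2)CCCCC1`: 57.6 nM

In a functional assay on MCF7 cells (Homo sapiens) for inhibition, read by MTT assay, with a stated time of 72 h (on this read-out lower numbers stand for stronger inhibition and higher numbers for weaker inhibition), compound 1 gives 619 nM, the highest of the three numbers; compound 2 is nearest, a 1.4-fold lower number from compound 1 to compound 2 (0.14 log units; within the scatter), and compound 3 furthest, an 11-fold lower number from compound 1 to compound 3 (1.03 log units; beyond the scatter). Compound 4 `O=C(Nc1ccc([N+](=O)[O-])cc1)C1(O)CCCCC1` differs from compound 1 by hydrogen in place of (2-iodophenyl)carbonyl on an oxygen on a saturated carbon. Going by the values given here, no measured step covers this change. The step that alters only a ring substituent stays within the scatter, while the step that exchanges the whole acyl group is large, so the acyl portion clearly matters in this assay. Removing it entirely goes further than either step, and a higher number is expected for compound 4, a 4.8-fold higher number from compound 1 to compound 4 (0.69 log units; beyond the scatter). Compound 4 is therefore estimated at 3000 nM, within 800 nM to 12000 nM.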

Compound 4, half-maximal inhibitory concentration: 664 nM
Estimate against measurement, compound 4: 4.5-fold (0.65 log units) above, and the stated range ends above it.
By their numbers in this assay, from the lowest: compound 3; then compounds 2, 1 and 4 (each within the scatter of the next).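

In this assay, hydrogen in place of (2-iodophenyl)carbonyl on this oxygen gives a 1.1-fold higher number from compound 1 to compound 4 (0.03 log units; within the scatter), so the level of compound 1 does not depend on that acyl group. The core of compound 4 reaches that level without any acyl group, and among the acyl groups shown, only the one in compound 3 at 57.6 nM stands apart from it. Nothing available explains this result.

The compounds shown leave open whether a small acetyl group or a methyl ether on this oxygen would match compound 3 or compound 4. They also leave open whether a saturated 2-phenylethyl chain would serve as well as the 2-phenylethenyl group.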